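Replacing Fluorines with Chlorines on an Antiproliferative Scaffold

The source may hold more compounds than are shown below. What is called first, only, known or untested is meant among the compounds shown, and "the series" means these compounds.

Compound 1, `COc1cc(C(=O)N/N=C/c2ccc(F)c(F)c2)cc(OC)c1OC`: 51.9%
Compound 2, `COc1cc(C2=NN(C(C)=O)C(c3ccccc3F)O2)cc(OC)c1OC`: 32.8%

Of the compounds shown here, two have been measured in a functional assay on BGC-823 cells (Homo sapiens) for antiproliferative activity, read by MTT assay, tested at 5 uM; a higher number here means a stronger effect of the compound at the concentration tested, a lower number a weaker effect. Compound 1 gives 51.9% in this assay, and compound 2 gives 32.8% there. Compound 1 thus stands highest of the two numbers, and its nearest neighbour, compound 2, lies lower by a gap beyond the scatter. For the measured compounds named here, the two compounds differ in more than one place, so no single-change step between measured compounds is available to guide the next move.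

Compound 3, `COc1cc(C(=O)N/N=C/c2ccc(Cl)c(Cl)c2)cc(OC)c1OC`, is the compound still to be measured. It differs from compound 1 in one place: 3,4-dichlorophenyl in place of 3,4-difluorophenyl on a carbon with a double bond to nitrogen. Because compound 1 gives 51.9%, and the change only exchanges one halogen pair for another on the same phenyl ring, the step of a number 6.1 percentage points higher from compound 1 to compound 3 (within the scatter) is expected to be small, upward if anything, and likely within the scatter. Compound 3 is estimated at 58%, with a range from 40% to 76%.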

Compound 3, a percentage reported as inhibition, at one concentration (the size of the read-out at that concentration, not a potency): 32.7%
For compound 3 the middle estimate is 25.3 percentage points above the measured one; measured number outside the range, below it.
By their numbers in this assay, from the lowest: compounds 3 and 2 (each within the scatter of the next); then compound 1.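

Exchanging 3,4-difluorophenyl for 3,4-dichlorophenyl on a carbon with a double bond to nitrogen gives a number 19.2 percentage points lower from compound 1 to compound 3 (beyond the scatter) in this assay. The two groups match in heavy atom count and in their carbon-only aromatic ring, and neither adds a hydrogen-bond donor or acceptor, yet the change from fluorine to chlorine alone moves the read-out, so this position is not indifferent to which halogen pair it carries. No measurement at hand bears on what lies behind this drop.

On these data alone, whether 3,4-dibromophenyl, or a phenyl ring bearing an amine or a carboxylic acid, would land nearer compound 1 or compound 3 stays open. A single step also cannot show whether the same halogen exchange would lower the read-out on a different core.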